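The source may report more compounds than this note shows. Statements on the series, on what has been measured and on what is new or still open speak of the compounds shown alone.

Measured compounds:
compound 1, `O=C(/C=C/c1ccc2c(c1)B(O)OC2)c1ccc(-c2ccccc2)cc1`, 4900 nM
compound 2, `O=C(/C=C/c1ccc2c(c1)B(O)OC2)c1cccnc1`, 18500 nM

Both were tested in a functional assay on SK-OV-3 cells (Homo sapiens) for cytotoxicity, read by MTT assay, with a stated time of 48 h; a lower number here means a stronger inhibitor, a higher number a weaker inhibitor. Compound 1 stands lowest of the two numbers; the nearest, compound 2, gives 18500 nM, a higher number by a margin beyond the scatter. Compound 3, `CCc1ccc(C(=O)/C=C/c2ccc3c(c2)B(O)OC3)cc1`, differs from compound 1 by ethyl in place of phenyl on an aromatic carbon. Among the compounds with values here, no measured pair shows this particular change, so its size can only be guessed from what the two measured compounds show. Compound 2, which carries a smaller aromatic group in that part of the molecule, gave the weaker result, so removing the phenyl is expected to cost somewhat, though an ethyl still occupies that site. The step of a 1.6-fold higher number from compound 1 to compound 3 (0.21 log units; within the scatter) is therefore expected to be a small weakening, near the edge of the scatter. Compound 3 is estimated at 8000 nM in this assay, within a range from 3000 nM to 22000 nM.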

Compound 3, half-maximal inhibitory concentration: 4400 nM
Compound 3: the middle estimate sits 1.8-fold (0.26 log units) above what was measured; low and high end bracket the measured number.
By their numbers in this assay, from the lowest: compounds 3 and 1 (each within the scatter of the next); then compound 2.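

Replacing phenyl with ethyl, on an aromatic carbon para to a large group, gives a 1.1-fold lower number from compound 1 to compound 3 (0.05 log units; within the scatter) in this assay and so leaves the two compounds level. Within the data shown here, this is the first direct reading at this position, and it shows that a phenyl ring is not required there to hold the number at this level, since compound 3 carries no ring at that place. Nothing available explains why phenyl and ethyl read alike here.

Going by these compounds, whether this tolerance reaches other kinds of group remains open, for instance an amine, a carboxylic acid, a longer chain such as hexyl, or a plain hydrogen at the same carbon. On these data alone, it is also open whether phenyl and ethyl would stay level on other cell lines.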